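Aryl amide swaps at the weak end of the series

The compounds below may be only part of what the source reports. "The series", "measured", "known", "first", "only" and "open" are said of these compounds alone.

Measured in a functional assay on A549 cells (Homo sapiens) for antiproliferative activity, read by MTT assay, with a stated time of 72 h; on this read-out lower numbers stand for stronger inhibition and higher numbers for weaker inhibition:
compound 1 `O=C(Nc1ccc(Cl)c(-c2nnc3c(Cl)cccn23)c1)c1ccccn1`: > 100000 nM (a limit)
compound 2 `O=C(Nc1ccc(Cl)c(-c2nnc3c(Cl)cccn23)c1)c1ccc(Cl)cc1`: 73600 nM
compound 3 `CS(=O)(=O)c1ccc(C(=O)Nc2ccc(Cl)c(-c3nnc4c(Cl)cccn34)c2)cc1`: > 100000 nM (a limit)

Compound 1 stands at a limit of this assay, > 100000 nM, and not at a number. The data so far are dominated by the limit of > 100000 nM in this assay, at which 2 of the 3 values shown sit.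

Compound 4 `Cc1cc(Cl)ccc1C(=O)Nc1ccc(Cl)c(-c2nnc3c(Cl)cccn23)c1` keeps the core of compound 1 and changes only the amide aryl group: 4-chloro-2-methylphenyl in place of pyridin-2-yl on a carbonyl carbon. The nearest measured change is an at least 1.3-fold lower number from compound 1 to compound 2 (0.13 log units; that floor lies within the scatter), which also puts a chlorine-bearing phenyl in place of pyridin-2-yl. The methylsulfonyl comparison gives an at least 1.3-fold higher number from compound 2 to compound 3 (0.13 log units; that floor lies within the scatter), while a step that the two limits leave unreadable from compound 1 to compound 3. Within the data shown here, no measured compound carries the 4-chloro-2-methylphenyl group, so the effect of its methyl is not covered by these data.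

The expectation therefore rests on compound 2 at 73600 nM, with no step beyond the scatter expected in this assay. The expected step is an at least 1.4-fold lower number from compound 1 to compound 4 (0.15 log units; that floor lies within the scatter). A reading at the limit would not be surprising. The estimate for compound 4 is 70000 nM, with an expected range of 30000 nM to 100000 nM.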

Compound 4, half-maximal inhibitory concentration: > 100000 nM
Compound 4 ended at the assay's limit; the forecaster's own chance of this, stated with the estimate: 40%; at least 1.4-fold (0.15 log units) between middle value and limit.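

In this assay, methyl in place of hydrogen on an aromatic carbon gives an at least 1.3-fold higher number from compound 2 to compound 4 (0.13 log units; that floor lies within the scatter), so the methyl adds no sign of stronger inhibition. Compound 4 reads as a limit and not a number, which shows that a chlorine-bearing phenyl on the carbonyl carbon does not by itself give a measurable value; among the compounds shown, only compound 2 has one. The steps from compound 1 and compound 3 to compound 4 join two limits and cannot be read, and the series stays pressed against one ceiling: the limit of > 100000 nM in this assay, at which 3 of the 4 values shown sit.

On these data alone, the size of the methyl step stays open, since compound 4 has no number. Also open, as far as these compounds go, is how an amine or a carboxylic acid on the amide aryl group, or a longer chain in its place, would read in this assay.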